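From 4-acetylphenyl to cycloheptyl on the amide nitrogen

A few compounds are considered here, and "the series" means these few. Any claim that something is new, unique, unknown or untested is made for them only; others in the source may bear on it.

Of the compounds shown here, three with a shared core have been tested in an ADME assay on MT2 cells (Homo sapiens) for cytotoxicity, read by XTT assay, with a stated time of 4 days; a lower number here means that less compound is tolerated, a higher number that more compound is tolerated. Compound 1 (`Cc1ccc(NC(=O)C(=O)NC(c2nc(C)c(CO)s2)C2CCCCN2)c(F)c1`) gives > 109000 nM, which is a limit of the assay. Compound 2 (`Cc1ccc(NC(=O)C(=O)NC(c2nc(C)c(CO)s2)C2CCCCN2)cc1F`) gives > 88000 nM, which is also a limit. Compound 3 (`CC(=O)c1ccc(NC(=O)C(=O)NC(c2nc(C)c(CO)s2)C2CCCCN2)cc1`) gives > 107000 nM, again a limit. Compound 3 therefore has no exact number, and the same holds for the other two, so no order among the three can be told.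

Compound 4 (`Cc1nc(C(NC(=O)C(=O)NC2CCCCCC2)C2CCCCN2)sc1CO`) differs from compound 3 in one place: cycloheptyl in place of 4-acetylphenyl on an amide-type nitrogen. Put simply, cycloheptyl sits in place of 4-acetylphenyl on an amide-type nitrogen. Three measured steps at this nitrogen bear on the change: a step that the two limits leave unreadable from compound 1 to compound 2, a step that the two limits leave unreadable from compound 1 to compound 3 and a step that the two limits leave unreadable from compound 2 to compound 3. None has a readable size, and none brings in cycloheptyl, so they offer only weak guidance. No step beyond the usual scatter is expected, in either direction. The estimated change is an at least 1.0-fold lower number from compound 3 to compound 4 (0.02 log units; that floor lies within the scatter). For compound 4 the estimated value is 100000 nM, with an expected range from 40000 nM to 160000 nM.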

Compound 4, half-maximal cytotoxic concentration: > 90000 nM
Compound 4 was reported as a limit; the forecaster's own chance of this, stated with the estimate: 70%; the middle value lies beyond the limit too.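

In this assay, for the compounds shown here, compound 4 is reported only as a limit, as are compound 1, compound 2 and compound 3, so no step from any of them to compound 4 can be read. The compounds shown leave open whether swapping the group on the amide-type nitrogen changes tolerance at all.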